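Hydrazone acid series: acetyl to carboxymethyl step

The compounds below may be only part of what the source reports. "The series", "measured", "known", "first", "only" and "open" are said of these compounds alone.

Compound 1 `CC1CC/C(=N\Nc2ccc(F)cc2)c2ncc(C(=O)O)c(=O)n21`, in a functional assay on the whole organism for inhibition, with Rattus norvegicus as the target (on this read-out lower numbers stand for an effect already at smaller amounts and higher numbers for an effect only at larger amounts of compound), compound 1 gives > 1000 umol/kg, a limit of the assay, not a number.
Compound 2 `CC(=O)c1ccc(N/N=C2\CCC(C)n3c2ncc(C(=O)O)c3=O)cc1`, in this assay compound 2 gives > 100 umol/kg, also only a limit.

Going by the values given here, both measured compounds therefore stand at limits, and the one measured step that the two limits leave unreadable from compound 1 to compound 2 cannot be read from them; the limit of > 1000 umol/kg in this assay, at which 1 of the 2 values shown sits, and the limit of > 100 umol/kg in this assay, at which 1 of the 2 values shown sits, mark where the two values sit. Compound 2 thus stands at a limit of this assay, with no measured number of its own.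

Compound 3 `CC1CC/C(=N\Nc2ccc(CC(=O)O)cc2)c2ncc(C(=O)O)c(=O)n21` differs from compound 2 in one place: carboxymethyl in place of acetyl on an aromatic carbon. Among the compounds with values here, no measured step bears on this change, since the single step is unreadable. For this assay no shift beyond the scatter is therefore expected, and the estimated step is a step that the limit leaves unreadable from compound 2 to compound 3. Compound 3 is expected to give about 300 umol/kg, within 50 umol/kg to 3000 umol/kg, most likely reported again as a limit rather than a number.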

Compound 3, dose for 50% inhibition: > 100 umol/kg
Compound 3 gave a limit, no number; the forecaster's own chance of this, stated with the estimate: 70%; the middle value lies beyond the limit too.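

In this assay compound 3 gives > 100 umol/kg, a limit and not a number. Going by these compounds alone, compound 1, compound 2 and compound 3 all stand at limits, and no step between them can be read. The compounds shown leave open what dose any of them needs for inhibition, and whether the group on the aromatic carbon changes it.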